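Urea series: ester in place of phenol, cytotoxicity

This account rests on a few compounds, and the source may have more. Where it says the series, first, only, none or still open, it means among the compounds named here.

Three members of the series have been tested in an ADME assay on HepG2 cells (Homo sapiens) for cytotoxicity, with a stated time of 72 h; on this read-out higher numbers stand for an effect only at larger amounts of compound and lower numbers for an effect already at smaller amounts. Compound 1 `COc1ccc(NC(=O)Nc2cc(C)nc3ccccc23)cc1` returns only a limit, > 25000 nM. Compound 2 `Cc1cc(NC(=O)Nc2ccc(N)cc2)c2ccccc2n1` likewise returns a limit, > 25000 nM. Compound 3 `Cc1cc(NC(=O)Nc2ccc(O)cc2)c2ccccc2n1` also returns a limit, > 25000 nM. All three therefore sit at the limit of > 25000 nM in this assay, at which 3 of the 3 values shown sit, and the steps a step that the two limits leave unreadable from compound 1 to compound 2, a step that the two limits leave unreadable from compound 1 to compound 3 and a step that the two limits leave unreadable from compound 2 to compound 3 cannot be sized. Compound 3 thus stands at the limit, with no numbered value anywhere in the set to place it against.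

Compound 4 `COC(=O)c1ccc(NC(=O)Nc2cc(C)nc3ccccc23)cc1` differs from compound 3 in one place: methoxycarbonyl in place of hydroxy on an aromatic carbon. Within the data shown here, no measured step involves a methoxycarbonyl; the three unreadable steps show only that methoxy, amino and hydroxy on an aromatic carbon all leave the read-out at the limit. With nothing numbered to build on, no step beyond the scatter is expected in this assay, and the likeliest outcome is that compound 4 again returns a limit. The expected value for compound 4 is 30000 nM, in the range 15000 nM to 60000 nM. The expected step is a step that the limit leaves unreadable from compound 3 to compound 4, essentially none.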

Compound 4, half-maximal effective concentration: 20000 nM
Compound 4: middle estimate off by 1.5-fold (0.18 log units), on the high side; low and high end bracket the measured number.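

Among the groups shown at this position, only methoxycarbonyl gives a numbered value in this assay: compound 4 gives 20000 nM. The change reads as an at least 1.2-fold lower number from compound 3 to compound 4 (0.09 log units; that floor lies within the scatter), as an at least 1.2-fold lower number from compound 2 to compound 4 (0.09 log units; that floor lies within the scatter) and as an at least 1.2-fold lower number from compound 1 to compound 4 (0.09 log units; that floor lies within the scatter), so each step is known only as a floor and none is shown to be a real change. Compound 4 is the only compound here with a number, and the other three remain at a limit: the limit of > 25000 nM in this assay, at which 3 of the 4 values shown sit.

Going by these compounds, the true size of all three steps stays open, and the steps among compounds 1, 2 and 3 cannot be read. Also open, on these data alone, is whether a carboxylic acid, a primary amide or a longer ester such as ethoxycarbonyl at this position would give a number in this assay.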